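Ethyl to Propyl Ester in a Thioester Amide Series

A few compounds are considered here, and "the series" means these few. Any claim that something is new, unique, unknown or untested is made for them only; others in the source may bear on it.

Measured so far:
Compound 1 `CCOC(=O)[C@@H](N)CCC(=O)NCCSC(C)=O` — 0.167 h
Compound 2 `CCOC(=O)[C@@H](N)CCC(=O)NCCSC(=O)C(C)(C)C` — 0.167 h

In an ADME assay on isolated protein for metabolic stability, with Cocaine esterase (Homo sapiens) as the target (a higher number here means that the compound lasts longer, a lower number that the compound disappears faster), compound 1 stands level with compound 2. Going by the values given here, the only step measured so far, no change at the digits printed from compound 1 to compound 2 (within the scatter), lies within the scatter and concerns the group on a carbonyl carbon, not the chain that compound 3 alters. Compound 3 `CCCOC(=O)[C@@H](N)CCC(=O)NCCSC(C)=O` differs from compound 1 by methyl in place of hydrogen on a saturated chain carbon, two bonds along the chain from an oxygen next to a carbonyl group. Among the compounds with values here, no measured step bears directly on this change, and the one known step was flat. On that basis the step of no change at the digits printed from compound 1 to compound 3 (within the scatter) is expected to stay within the scatter. Compound 3 is therefore expected to give 0.167 h, with a range from 0.08 h to 0.35 h.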

Compound 3, half-life in the Cocaine esterase assay: 0.167 h
Compound 3: the middle estimate sits on the measured number at the digits printed, and the stated range covers the measured number.
By their numbers in the Cocaine esterase assay, from the lowest: compounds 1, 2 and 3 (each within the scatter of the next).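

The earlier compounds shown here share one ester chain, whereas here, in the Cocaine esterase assay, ethoxy to propoxy gives no change at the digits printed from compound 1 to compound 3 (within the scatter). In a physicochemical assay for lipophilicity, at pH 7.4 (a lower number here means a more polar compound, a higher number a more lipophilic compound), compound 1 gives -1.44 and compound 3 gives -1.21, values within the scatter of each other. Nothing available bears on the reason for this result.

On these data alone, whether a longer chain on the ester oxygen would move the half-life remains open. So does the effect of a carboxylic acid in place of the ester.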